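Swapping a diaryl ether for a thioether on a shared core

This account rests on a few compounds, and the source may have more. Where it says the series, first, only, none or still open, it means among the compounds named here.

Compound 1: `Nc1cc(N)c2nc(-c3ccccc3)c(Oc3ccc(Cl)c(Cl)c3)nc2c1` — < 100000 nM
Compound 2: `COc1cc(CNc2nc3cc(N)cc(N)c3nc2-c2ccccc2)cc(OC)c1OC` — 8710 nM

Two compounds built on the same core were tested in a functional assay on CAKI-1 cells (Homo sapiens) for inhibition, read by sulforhodamine B assay, with a stated time of 48 h; on this read-out lower numbers stand for stronger inhibition of growth and higher numbers for weaker inhibition of growth. On these data alone, for compound 1 the result is a limit of the assay rather than a number, < 100000 nM, so its exact place on the scale stays open. Compound 2 gives 8710 nM in this assay. Going by the values given here, no pair among the measured compounds differs in just one place, so no single step has been measured, and the only evidence about compound 1 is the limit itself (the limit of < 100000 nM in this assay, at which 1 of the 2 values shown sits).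

Compound 3, `Nc1cc(N)c2nc(-c3ccccc3)c(Sc3ccc(F)cc3)nc2c1`, has not yet been measured in this assay. It differs from compound 1 at one site: (4-fluorophenyl)sulfanyl in place of 3,4-dichlorophenoxy on an aromatic carbon. With compound 1 known only as a limit, the size of the step cannot be read from the data, so the expectation rests on the spread of the two values given.

Compound 3 is expected to give about 25000 nM in this assay, with a range from 4000 nM to 100000 nM. The step this estimate means from compound 1 to compound 3 is a step that the limit leaves unreadable from compound 1 to compound 3, an expected direction only, and the outcome may again be a limit.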

Compound 3, concentration for total growth inhibition: < 100000 nM
Compound 3 was reported as a limit; the forecaster's own chance of this, stated with the estimate: 30%; the middle value does not contradict the limit.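

Compound 1 and compound 3 are each reported in this assay only as a limit of the assay, not as a number, so no step between them can be read: the limit of < 100000 nM in this assay, at which 2 of the 3 values shown sit.

The compounds shown leave open whether (4-fluorophenyl)sulfanyl in place of 3,4-dichlorophenoxy changes the inhibition of growth at all, and in which direction.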